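The source may report more compounds than this note shows. Statements on the series, on what has been measured and on what is new or still open speak of the compounds shown alone.

Measured so far in a toxicity assay on HT-29 cells (Homo sapiens) for cytotoxicity; a higher number here means that more compound is tolerated, a lower number that less compound is tolerated:

compound 1 `CCCCCn1nc(C(=O)N[C@H]2COc3ccccc3N(C)C2=S)nc1Cc1ccccc1` — > 100000 nM
compound 2 `CN1C(=S)[C@@H](NC(=O)c2nc(Cc3ccccc3)n(CCC(F)(F)F)n2)COc2ccccc21` — > 100000 nM
compound 3 `CN1C(=S)[C@@H](NC(=O)c2nc(Cc3ccccc3)n(C3CCCC3)n2)COc2ccccc21` — > 100000 nM

The value for compound 1 is a limit of the assay, not a number. The value for compound 2 is likewise a limit. The value for compound 3 is also only a limit, so compound 3 stands nowhere readable within the series: all three values sit at the limit of > 100000 nM in this assay, at which 3 of the 3 values shown sit.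

Compound 4 `CN1C(=S)[C@@H](NC(=O)c2nc(Cc3ccccc3)n(C3CCNCC3)n2)COc2ccccc21` is not yet measured. It differs from compound 3 at the aromatic nitrogen: piperidin-4-yl in place of cyclopentyl on an aromatic nitrogen.

For the measured compounds named here, the steps that bear on this change are the earlier swaps on the same aromatic nitrogen, a step that the two limits leave unreadable from compound 1 to compound 3 and a step that the two limits leave unreadable from compound 2 to compound 3, together with a step that the two limits leave unreadable from compound 1 to compound 2. None of them has a readable size, since every compound involved sits at the same limit. Nothing in the series therefore points to a step beyond the scatter in this assay for compound 4, and no numeric size can be read for it.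

Compound 4 is expected to come out at the same limit, with an estimate of 100000 nM, ranging from 40000 nM to 300000 nM. The expected step is a number no higher from compound 3 to compound 4 (the limit leaves the size open).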

Compound 4, half-maximal cytotoxic concentration: > 100000 nM
Compound 4: a limit, no number (the forecaster's own chance of this, stated with the estimate: 85%); the middle value sits exactly at the limit.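

In this assay compound 4 gives > 100000 nM, which is a limit and not a number. Its steps from compound 1, compound 2 and compound 3 cannot be read, since all four compounds share one limit: the limit of > 100000 nM in this assay, at which 4 of the 4 values shown sit.

The compounds shown leave open whether the groups on the aromatic nitrogen differ at all in this assay.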